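The source may hold more compounds than are shown below. What is called first, only, known or untested is meant among the compounds shown, and "the series" means these compounds.

In a functional assay on ACHN cells (Homo sapiens) for antiproliferative activity, read by MTT assay, with a stated time of 96 h (on this read-out higher numbers stand for weaker inhibition and lower numbers for stronger inhibition), compound 1, `O=C1NC(=O)C2(CSC3=C2C(=O)c2ncccc2C3=O)N1`, gives 80 nM. Compound 2, `O=C1C2=C(C(=O)c3ncccc31)C1(CS2)NC(=O)N(c2ccc([N+](=O)[O-])cc2)C1=O`, gives 100 nM in this assay, and the change from compound 1 to compound 2, 4-nitrophenyl in place of hydrogen on an amide-type nitrogen in a ring, gives a 1.3-fold higher number from compound 1 to compound 2 (0.10 log units; within the scatter). Compound 3, `O=C1C2=C(C(=O)c3ncccc31)C1(CS2)NC(=O)N(c2ccccc2)C1=O`, gives 21 nM in this assay and stands lowest of the three numbers: phenyl in place of hydrogen on the same nitrogen gives a 3.8-fold lower number from compound 1 to compound 3 (0.58 log units; beyond the scatter), and hydrogen in place of nitro on an aromatic carbon gives a 4.8-fold lower number from compound 2 to compound 3 (0.68 log units; beyond the scatter).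

Compound 4, `CCCCCc1ccc(N2C(=O)NC3(CSC4=C3C(=O)c3ncccc3C4=O)C2=O)cc1`, differs from compound 3 by pentyl in place of hydrogen on an aromatic carbon. For the measured compounds named here, no measured step concerns a pentyl group. Going by the values given here, the only step on that aromatic ring is the one from compound 2 to compound 3, where removing the nitro gave a modest lowering, so a group at this place can move the number beyond the scatter, while the nitrophenyl step from compound 1 to compound 2 stayed within it. The direction for pentyl cannot be read from these steps, so the expectation for compound 4 is a step near the scatter, a 1.5-fold higher number from compound 3 to compound 4 (0.18 log units; within the scatter), with a wide range. Compound 4 is therefore estimated at 32 nM, between 12 nM and 85 nM.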

Compound 4, half-maximal inhibitory concentration: 250 nM
For compound 4 the middle estimate is 7.8-fold (0.89 log units) below the measured one; the measured number lies above the stated range.
By their numbers in this assay, from the lowest: compound 3; then compounds 1 and 2 (each within the scatter of the next); then compound 4.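

In this assay, for the compounds shown here, the earlier compounds showed only that a nitro group on this aromatic carbon, para to a large group, gives a higher number than hydrogen; pentyl shows that a group with no hydrogen-bond donors or acceptors can have a much larger effect at the same place (a 12-fold higher number from compound 3 to compound 4 (1.08 log units; beyond the scatter)), the largest step in the set. The two groups at this place also differ from each other beyond the scatter (a 2.5-fold higher number from compound 2 to compound 4 (0.40 log units; beyond the scatter)), so the outcome here depends on which group is present, and both of the groups shown give a higher number than hydrogen, leaving compound 3 with the lowest value of the set. No evidence is available to explain why pentyl has this effect.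

The compounds shown leave open whether the number climbs gradually with chain length, which a methyl or propyl group at this carbon would test, or whether any chain is enough. They also leave open whether a group such as an amine, a methoxy or a carboxylic acid at this place could keep the number near that of compound 3 or take it lower.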